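The source may hold more compounds than are shown below. What is called first, only, known or untested is meant among the compounds shown, and "the series" means these compounds.

Of the compounds shown here, three share one core and have been measured in a functional assay on PC-3 cells (Homo sapiens) for cytotoxicity, read by MTT assay, with a stated time of 72 h; a higher number here means a weaker inhibitor, a lower number a stronger inhibitor. Compound 1 `O=C(Nc1ccc(Oc2ccnc3[nH]ccc23)cc1)c1nn(-c2ccc(Br)cc2)ccc1=O` gives 8040 nM. Compound 2 `O=C(Nc1ccc(Oc2ccnc3[nH]ccc23)cc1)c1nn(-c2ccc(Cl)c(F)c2)ccc1=O` gives 7780 nM. Compound 3 `O=C(Nc1ccc(Oc2ccnc3[nH]ccc23)c(F)c1)c1nn(-c2ccc(Br)cc2)ccc1=O` gives 40800 nM, which is the highest of the three numbers; the nearest to it is compound 1, and the step is a 5.1-fold higher number from compound 1 to compound 3 (0.71 log units; beyond the scatter), while the step from compound 1 to compound 2 is a 1.0-fold lower number from compound 1 to compound 2 (0.01 log units; within the scatter).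

Compound 4 `O=C(Nc1ccc(Oc2ccnc3[nH]ccc23)c(F)c1)c1nn(-c2ccc(Cl)c(F)c2)ccc1=O` has not yet been measured. It differs from compound 3 in one place: 4-chloro-3-fluorophenyl in place of 4-bromophenyl on an aromatic nitrogen.

Going by the values given here, one measured step bears directly on this change. The same exchange, 4-chloro-3-fluorophenyl in place of 4-bromophenyl on the aromatic nitrogen, has already been made on the parent lacking the fluoro group, and there the step from compound 1 to compound 2 was a 1.0-fold lower number from compound 1 to compound 2 (0.01 log units; within the scatter), within the scatter. Nothing in the three measured compounds suggests that the fluoro on the aromatic carbon alters how this exchange behaves, so compound 4 is expected to give a number close to that of compound 3, with a step of a 1.0-fold lower number from compound 3 to compound 4 (0.01 log units; within the scatter) expected, and no shift beyond the scatter. Compound 4 is therefore estimated at 40000 nM in this assay, with a range of 16000 nM to 100000 nM.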

Compound 4, half-maximal inhibitory concentration: 13600 nM
Beside the measured number, compound 4's estimate is 2.9-fold (0.47 log units) above it, outside the stated range (below it).
By their numbers in this assay, from the lowest: compounds 2, 1 and 4 (each within the scatter of the next); then compound 3.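

In this assay, 4-chloro-3-fluorophenyl in place of 4-bromophenyl on the aromatic nitrogen proves to matter on the fluoro-bearing core, with a 3.0-fold lower number from compound 3 to compound 4 (0.48 log units; beyond the scatter), so the outcome of this exchange depends on the core that carries it: the same change on two cores in this assay, a 1.0-fold lower number (0.01 log units; within the scatter) from compound 1 to compound 2 and a 3.0-fold lower number (0.48 log units; beyond the scatter) from compound 3 to compound 4, 2.9-fold (0.46 log units) apart, beyond the scatter of two such steps

Read the other way, fluoro in place of hydrogen on the aromatic carbon no longer gives a step beyond the scatter once 4-chloro-3-fluorophenyl is present, with a 1.7-fold higher number from compound 2 to compound 4 (0.24 log units; within the scatter), which differs from what the same change does with 4-bromophenyl: the same change on two cores in this assay, a 5.1-fold higher number (0.71 log units; beyond the scatter) from compound 1 to compound 3 and a 1.7-fold higher number (0.24 log units; within the scatter) from compound 2 to compound 4, 2.9-fold (0.46 log units) apart, beyond the scatter of two such steps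

The two changes therefore do not act independently in these four compounds, and the loss seen with the added fluoro is so far clear only in the pairing of that fluoro with 4-bromophenyl, in compound 3.

The compounds shown leave open whether the chlorine in place of bromine or the added fluorine on the phenyl ring carries this dependence, a question that a plain 4-chlorophenyl group on both cores would address. They also leave open how a different substituent on that phenyl ring, such as a methoxy group or an amine, would behave on either core.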